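Thiazole to triazole swap at the ring amine nitrogen

The source may report more compounds than this note shows. Statements on the series, on what has been measured and on what is new or still open speak of the compounds shown alone.

Compound 2 `NC(=O)c1csc(N2CCC(Oc3ccccc3C(F)(F)F)CC2)n1` holds the lowest of the two numbers in an assay on microsomes from liver (strain Wistar) for inhibition of acyl-CoA desaturase 1 (Rattus norvegicus), read by HPLC, with stated times of 1 h and 60 min; on this read-out lower numbers stand for stronger inhibition and higher numbers for weaker inhibition. Compound 3 `NC(=O)c1nc(N2CCC(Oc3ccccc3C(F)(F)F)CC2)no1` gives 1630 nM in this assay, a step from compound 2 at 676 nM of a 2.4-fold higher number from compound 2 to compound 3 (0.38 log units; beyond the scatter). Compound 1 `NC(=O)c1cnc(N2CCN(S(=O)(=O)c3ccccc3C(F)(F)F)CC2)s1`, a sulfonamide-linked analogue, reaches only the limit of this assay at > 3000 nM, where (the limit of > 3000 nM in this assay, at which 1 of the 3 values shown sits). Compound 4 `NC(=O)c1n[nH]c(N2CCC(Oc3ccccc3C(F)(F)F)CC2)n1` is the unmeasured member; its change from compound 2 is 3-carbamoyl-1H-1,2,4-triazol-5-yl in place of 4-carbamoyl-1,3-thiazol-2-yl on an amine nitrogen in a ring. Among the compounds with values here, the only measured step that bears on this change is the exchange of the same five-membered carbamoyl-bearing ring for another, the step from compound 2 to compound 3, which was modest and ran toward weaker inhibition. A second swap of that ring is therefore expected to move this assay in the same direction by a comparable, modest size, and no more. Compound 4 is estimated at 1500 nM in this assay, within 500 nM to 4500 nM, meaning an expected step of a 2.2-fold higher number from compound 2 to compound 4 (0.35 log units; beyond the scatter).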

Compound 4, half-maximal inhibitory concentration: 127 nM
Estimate against measurement, compound 4: 12-fold (1.07 log units) above; the measured number lies below the stated range.
By their numbers in this assay, from the lowest: compound 4; then compound 2; then compound 3. At a limit, above all of these: compound 1.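

Within the data shown here, the ring on the amine nitrogen can shift this assay in either direction: exchanging one five-membered carbamoyl-bearing ring for another gives a 5.3-fold lower number from compound 2 to compound 4 (0.73 log units; beyond the scatter), whereas the only earlier exchange had raised the number. The size of a 13-fold lower number from compound 3 to compound 4 (1.11 log units; beyond the scatter) shows that this place separates rings of equal heavy-atom count, so the identity of the ring matters here and not merely the presence of a carbamoyl-bearing five-membered ring. Nothing in the evidence shown bears on why the number falls with this change.

Still open, going by these compounds, is whether the lower number depends on the hydrogen of the triazole ring, which a methyl group there would test, and whether the carbamoyl is needed, which a nitrile or carboxylic acid in its place would test. Also open, on these data alone, is how the 3-carbamoyl-1H-1,2,4-triazol-5-yl group behaves when chlorine or a methoxy group replaces the trifluoromethyl.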